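Cytotoxicity notes: aryl amide in place of carbamate

The source may hold more compounds than are shown below. What is called first, only, known or untested is meant among the compounds shown, and "the series" means these compounds.

Measured compounds in an ADME assay on Vero cells (Chlorocebus sabaeus) for cytotoxicity, read by resazurin assay, with a stated time of 3 days; on this read-out higher numbers stand for weaker inhibition and lower numbers for stronger inhibition:
compound 1 `CCOCCOC(=O)Nc1cc2nc(C3CCCCC3)[nH]c2cc1N(C)C` gives > 100 ug/mL, a limit of the assay.
compound 2 `CCCNC(=O)Nc1cc2nc(C3CCCCC3)[nH]c2cc1N1CCCC1` gives > 100 ug/mL, a limit of the assay.
compound 3 `CCOCCOC(=O)Nc1cc2nc(C3CCCCC3)[nH]c2cc1N1CCCC1` gives > 100 ug/mL, a limit of the assay.

Compound 1 stands only at a limit in this assay, and the two other values shown are limits as well; this is summed up by the limit of > 100 ug/mL in this assay, at which 3 of the 3 values shown sit. The two single-point steps among the measured compounds are therefore not readable: a step that the two limits leave unreadable from compound 1 to compound 3 and a step that the two limits leave unreadable from compound 2 to compound 3 give no size and no direction.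

The next compound, compound 4 `CN(C)c1cc2[nH]c(C3CCCCC3)nc2cc1NC(=O)c1cccc(Br)c1`, differs from compound 1 in one place: 3-bromophenyl in place of 2-ethoxyethoxy on a carbonyl carbon. Among the compounds with values here, no measured step concerns a change on the carbonyl carbon of this kind, and none of the measured steps yields a readable size, so no direction can be taken from them. With every measured value of the series sitting at the limit, the working expectation for compound 4 is that this assay again reports a value near the limit, with the step estimated as a number no higher from compound 1 to compound 4 (the limit leaves the size open). On that basis compound 4 is estimated at 100 ug/mL, within 40 ug/mL to 200 ug/mL.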

Compound 4, half-maximal inhibitory concentration: > 100 ug/mL
Compound 4: a limit, no number; the forecaster's own chance of this, stated with the estimate: 60%; the middle value lies on the limit itself.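

Compound 4 gives > 100 ug/mL in this assay, a limit of the assay. The change from compound 1 to compound 4 therefore yields no readable step: the limit of > 100 ug/mL in this assay, at which 4 of the 4 values shown sit.

The compounds shown leave open whether any change on the shared core alters this read-out, and by how much.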